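The source may hold more compounds than are shown below. What is called first, only, known or untested is meant among the compounds shown, and "the series" means these compounds.

Measured compounds:
- compound 1, `CC1(C)CCC(C)(C)c2cc(C(=O)c3ccc4cc(C(=O)O)ccc4c3)c(O)cc21`; in an assay on isolated protein with retinoic acid receptor beta (Homo sapiens) as the target (on this read-out higher numbers stand for larger maximal responses and lower numbers for smaller maximal responses), compound 1 gives 76%
- compound 2, `Cc1cc2c(cc1C(=O)c1ccc3cc(C(=O)O)ccc3c1)C(C)(C)CCC2(C)C`; in this assay compound 2 gives 81%
- compound 3, `CC1(C)CCC(C)(C)c2cc(C(O)c3ccc4cc(C(=O)O)ccc4c3)c(O)cc21`; in this assay compound 3 gives 18%

Compound 1 and compound 2 differ in one place only: methyl in place of hydroxy on an aromatic carbon. The step is a number 5 percentage points higher from compound 1 to compound 2 (within the scatter), so the two cannot be told apart on this read-out. Compound 3 carries a different core; the difference between the core of compound 3 and the core of compound 1 is not broken down here. Compound 3 stands lowest of the three, with compound 1 and compound 2 both beyond the scatter above it.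

Compound 4, `Cc1cc2c(cc1C(O)c1ccc3cc(C(=O)O)ccc3c1)C(C)(C)CCC2(C)C`, is not yet measured in this assay. It differs from compound 3 by methyl in place of hydroxy on an aromatic carbon. The place is described in the same words as for the change from compound 1 to compound 2, so this is the same change, made twice in the series.

For the measured compounds named here, the only measured instance of this change is the step from compound 1 to compound 2, and because a number 5 percentage points higher from compound 1 to compound 2 (within the scatter) was within the scatter, a small step is expected from compound 3 to compound 4 as well, estimated at a number 5 percentage points higher from compound 3 to compound 4 (within the scatter). This rests on a single pair and is carried over onto a different core, which widens the range. For compound 4 the expected value in this assay is 23%, estimated to lie between 10% and 40%.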

Compound 4, largest response reached (reported as maximum), in percent of the reference or control that the assay uses: 96%
Compound 4: the middle estimate sits 73 percentage points below what was measured, outside the stated range (above it).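

In this assay, methyl in place of hydroxy on an aromatic carbon gives a number 78 percentage points higher from compound 3 to compound 4 (beyond the scatter), so on the core of compound 3 this change moves the maximal response by a large amount, and compound 4 reaches 96%. Carrying the change from one core to another in this series therefore cannot rest on the size of the step seen on the first core, and the two steps do not agree: the same change on two cores in this assay, a number 5 percentage points higher (within the scatter) from compound 1 to compound 2 and a number 78 percentage points higher (beyond the scatter) from compound 3 to compound 4, 73 percentage points apart, beyond the scatter of two such steps. These two pairs show that the size of the step depends on the core in this series, but they do not show which feature of the cores is responsible, why the steps differ, or how the change would behave on any further core.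

Going by these compounds, it remains open how other groups on the same aromatic carbon would behave on each of the two cores, for example an ethyl, a methoxy or an amine, and whether any of them would give a small step on one core and a large step on the other. On these data alone, it is equally open whether an amide in place of the carboxylic acid would leave this dependence on the core intact.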